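Swapping a pyridine for a pyrazole on the benzyl arm

The compounds below may be only part of what the source reports. "The series", "measured", "known", "first", "only" and "open" are said of these compounds alone.

Measured so far:
Compound 1, `Cc1cc(C)c(NC(=O)N(Cc2ccc(N3CCN(C)CC3)cc2)C2CCCCCC2)c(C)c1` — > 1 mg/kg
Compound 2, `Cc1cc(C)c(NC(=O)N(Cc2ccc(-c3cccnc3)cc2)C2CCCCCC2)c(C)c1` — 0.58 mg/kg

Two compounds share the same urea core and differ only in the group attached to the benzyl ring. In a functional assay on a cell-free system (plasma) with sterol O-acyltransferase, Soat (Rattus norvegicus) as the target (a lower number here means that less compound is needed, a higher number that more compound is needed for the effect), compound 1 gives > 1 mg/kg, which is a limit of the assay rather than a number. In this assay, within the data shown here, compound 2 gives 0.58 mg/kg, the only actual number so far, so compound 2 stands alone as the measured point of reference. Among the measured compounds shown here, the only measured step runs an at least 1.7-fold lower number from compound 1 to compound 2 (0.23 log units; that floor lies within the scatter), and it is anchored on one side by the limit of > 1 mg/kg in this assay, at which 1 of the 2 values shown sits, so its true size is not known.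

Compound 3, `Cc1cc(C)c(NC(=O)N(Cc2ccc(-n3cccn3)cc2)C2CCCCCC2)c(C)c1`, carries the change (1H-pyrazol-1-yl in place of pyridin-3-yl on an aromatic carbon). For the measured compounds named here, no measured step involves a pyrazole, so the one step available, an at least 1.7-fold lower number from compound 1 to compound 2 (0.23 log units; that floor lies within the scatter), bears on it only loosely: it shows that exchanging the group at this position can move the number, but not how a pyrazole will do. A change near or within the scatter is therefore expected, with a wide range. For compound 3 the estimate in this assay is 0.8 mg/kg, ranging from 0.3 mg/kg to 3 mg/kg. That estimate corresponds to an expected step of a 1.4-fold higher number from compound 2 to compound 3 (0.14 log units; within the scatter).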

Compound 3, dose for half-maximal effect: > 1 mg/kg
Compound 3: only a limit was reported; the forecaster's own chance of this, stated with the estimate: 30%; at least 1.2-fold (0.09 log units) between middle value and limit.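

In this assay compound 3 gives > 1 mg/kg, which is a limit of the assay and not a number. Replacing the six-membered pyridin-3-yl ring with the five-membered 1H-pyrazol-1-yl ring gives an at least 1.7-fold higher number from compound 2 to compound 3 (0.23 log units; that floor lies within the scatter), so the result hints that this exchange may not be neutral, but the printed floor of the step does not separate the two compounds beyond the scatter. Compound 2 remains the only compound with a measured number, and the 1H-pyrazol-1-yl group joins 4-methylpiperazin-1-yl as a second group on this aromatic carbon that ends at a limit, which leaves the view of this position coarse: the limit of > 1 mg/kg in this assay, at which 2 of the 3 values shown sit.

On these data alone, how far compound 3 lies past its limit stays unknown, and the step between compound 1 and compound 3, with limits at both ends, cannot be read. Also open, as far as these compounds go, is how other groups on this aromatic carbon, such as a phenyl ring, a pyridin-4-yl ring or a simple amine, would compare with the pyridin-3-yl group of compound 2.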